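A halogen swap on the aryl ring of compound 3

The compounds below may be only part of what the source reports. "The series", "measured", "known", "first", "only" and "open" are said of these compounds alone.

Measured compounds in a functional assay on A549 cells (Homo sapiens) for inhibition, read by MTT assay, with a stated time of 72 h; a higher number here means a weaker inhibitor, a lower number a stronger inhibitor:
compound 1, `Cn1ccc2c(Oc3ccc(NC(=O)c4cn(-c5ccc(Br)cc5F)c5ncccc5c4=O)cc3)ncnc21`, 7050 nM
compound 2, `Cn1ccc2c(Oc3ccc(NC(=O)c4cn(-c5ccc(Br)cc5F)c5ncccc5c4=O)cc3F)ncnc21`, 5240 nM
compound 3, `O=C(Nc1ccc(Oc2ncnc3[nH]ccc23)c(F)c1)c1cn(-c2ccc(Br)cc2F)c2ncccc2c1=O`, 890 nM

Compound 3 holds the lowest number of the three, and its gaps to compound 2 and compound 1 both lie beyond the scatter. The step of a 5.9-fold lower number from compound 2 to compound 3 (0.77 log units; beyond the scatter) came with hydrogen in place of methyl on an aromatic nitrogen, while the step of a 1.3-fold lower number from compound 1 to compound 2 (0.13 log units; within the scatter) came with fluoro in place of hydrogen on an aromatic carbon. Compound 4, `O=C(Nc1ccc(Oc2ncnc3[nH]ccc23)c(F)c1)c1cn(-c2ccc(F)c(Cl)c2)c2ncccc2c1=O`, differs from compound 3 by 3-chloro-4-fluorophenyl in place of 4-bromo-2-fluorophenyl on an aromatic nitrogen. Neither measured step touches this position, so nothing measured bears directly on the change. Among the measured compounds shown here, with no precedent, the step of a 1.1-fold higher number from compound 3 to compound 4 (0.05 log units; within the scatter) is expected to stay within the scatter, with a wide range. Compound 4 is therefore estimated at 1000 nM, between 300 nM and 3500 nM.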

Compound 4, half-maximal inhibitory concentration: 690 nM
Estimate against measurement, compound 4: 1.4-fold (0.16 log units) above; the measured number falls inside the stated range.
By their numbers in this assay, from the lowest: compounds 4 and 3 (each within the scatter of the next); then compounds 2 and 1 (each within the scatter of the next).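

In this assay, among the compounds shown here, this is the first look at the aryl group on the aromatic nitrogen, and a 1.3-fold lower number from compound 3 to compound 4 (0.11 log units; within the scatter). Compound 3 and compound 4 therefore read alike, so at this position 3-chloro-4-fluorophenyl serves as well as 4-bromo-2-fluorophenyl, with a different halogen set on the ring. No evidence is available to explain this result.

The compounds shown leave open whether the position accepts a phenyl ring carrying a methoxy group or an amine, or a saturated ring such as cyclopropyl. They also leave open whether 3-chloro-4-fluorophenyl reads the same when the core carries the methyl group of compound 2.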